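A few compounds are considered here, and "the series" means these few. Any claim that something is new, unique, unknown or untested is made for them only; others in the source may bear on it.

Measured compounds:
compound 1 `Fc1cccc(F)c1C#Cc1ccc2c(Cl)ccnc2c1`: 70.8%
compound 2 `Nc1ccnc2ccc(C#Cc3c(F)cccc3F)cc12`: 93.9%

In a functional assay on LS174T cells (Homo sapiens) for inhibition, with a stated time of 4 days, tested at 10 uM (a higher number here means a stronger effect of the compound at the concentration tested, a lower number a weaker effect), compound 2 gives 93.9%, the highest of the two numbers; compound 1 gives 70.8%, a number lower by more than the scatter. Compound 3 `Fc1cccc(F)c1C#Cc1ccc2ncccc2c1` differs from compound 2 in one place: hydrogen in place of amino on an aromatic carbon. Compound 1, which also lacks the amino, gives 70.8% in this assay, so a downward step beyond the scatter is expected. Compound 3 is therefore estimated to give 55%, within 30% to 80%. This estimate means an expected step of a number 38.9 percentage points lower from compound 2 to compound 3 (beyond the scatter).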

Compound 3, a percentage reported as inhibition, at one concentration (the size of the read-out at that concentration, not a potency): 80.1%
Beside the measured number, compound 3's estimate is 25.1 percentage points below it; the whole stated range lies below it.
By their numbers in this assay, from the lowest: compounds 1 and 3 (each within the scatter of the next); then compound 2.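

In this assay the amino group opposite the ring nitrogen does contribute, with a number 13.8 percentage points lower from compound 2 to compound 3 (beyond the scatter) on its replacement by hydrogen, but the effect does not depend on it: compound 3 still gives 80.1% at the concentration tested. The step is a modest one, so this position tolerates the loss of the amino group. Nothing measured here accounts for the step. The compounds shown leave open how a methylamino group, a dimethylamino group, a hydroxyl or a methoxy group would read at this same position. They also leave open whether an amide there would keep the effect.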